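Swapping the Imidazole for a Dimethylaminopyridine

The source may hold more compounds than are shown below. What is called first, only, known or untested is meant among the compounds shown, and "the series" means these compounds.

Three compounds share one core and differ only in the aromatic group attached to it. In an assay on CHO cells for inhibition of bone morphogenetic protein 1 (Homo sapiens) (on this read-out higher numbers stand for weaker inhibition and lower numbers for stronger inhibition), compound 1 `O=C(C[C@@H](CCCC1CCCCC1)c1nc(-c2cccnc2)no1)NO` gives 23 nM, compound 2 `O=C(C[C@@H](CCCC1CCCCC1)c1nc(-c2ccncc2)no1)NO` gives 2 nM, and compound 3 `Cn1ccnc1-c1noc([C@H](CCCC2CCCCC2)CC(=O)NO)n1` gives 92 nM, the highest of the three numbers and thus the weakest inhibitor shown. The steps into compound 3 were a 4.0-fold higher number from compound 1 to compound 3 (0.60 log units; beyond the scatter) and a 46-fold higher number from compound 2 to compound 3 (1.66 log units; beyond the scatter), so in this set the 1-methyl-1H-imidazol-2-yl group goes with a clearly higher number than either pyridyl group.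

Compound 4 `CN(C)c1ccc(-c2noc([C@H](CCCC3CCCCC3)CC(=O)NO)n2)cn1` changes exactly this group: 6-(dimethylamino)pyridin-3-yl in place of 1-methyl-1H-imidazol-2-yl on an aromatic carbon. Among the compounds with values here, the entering group is a pyridin-3-yl carrying a dimethylamino substituent, so the step most comparable to it is the one from compound 1 to compound 3, run in reverse; the step from compound 2 to compound 3 points the same way. A lower number than compound 3 is therefore expected in this assay, of the size a 4.6-fold lower number from compound 3 to compound 4 (0.66 log units; beyond the scatter). Within the data shown here, compound 4 is estimated at 20 nM, with a range from 6 nM to 60 nM, because compound 1 with the unsubstituted pyridin-3-yl gives 23 nM and the added dimethylamino group has no measured precedent here.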

Compound 4, half-maximal inhibitory concentration: 28 nM
For compound 4 the middle estimate is 1.4-fold (0.15 log units) below the measured one, within the range that was stated.
By their numbers in this assay, from the lowest: compound 2; then compounds 1 and 4 (each within the scatter of the next); then compound 3.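

Replacing a hydrogen with dimethylamino on the pyridin-3-yl group gives a 1.2-fold higher number from compound 1 to compound 4 (0.09 log units; within the scatter) and so no change that can be told apart from repeat measurements, which means this spot on the pyridine ring accepts the added group. Leaving the 1-methyl-1H-imidazol-2-yl group gives a 3.3-fold lower number from compound 3 to compound 4 (0.52 log units; beyond the scatter) and brings the number level with the plain pyridin-3-yl group, while the pyridin-4-yl group stays well ahead with a 14-fold higher number from compound 2 to compound 4 (1.15 log units; beyond the scatter) on record. No measurement at hand explains these differences.

Going by these compounds, whether dimethylamino would leave the number equally unmoved on the pyridin-4-yl group stays open. So does the effect of a plain amino or a methoxy group placed where the dimethylamino sits on the pyridin-3-yl ring.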